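The source may hold more compounds than are shown below. What is called first, only, known or untested is meant among the compounds shown, and "the series" means these compounds.

Working notes on the acyl-CoA:cholesterol acyltransferase series. Of the compounds shown here, three have been measured in an assay on microsomes from intestine for inhibition of acyl-CoA:cholesterol acyltransferase (Oryctolagus cuniculus); on this read-out higher numbers stand for weaker inhibition and lower numbers for stronger inhibition. Compound 1 `Cc1cc(C)c(NC(=O)N(Cc2cc(-c3ccccc3)cs2)C2CCCCCC2)c(C)c1` gives 36 nM. Compound 2 `Cc1cc(C)c(NC(=O)N(Cc2ccc(-c3n[nH]c(C)n3)cc2)C2CCCCCC2)c(C)c1` gives 120 nM. Compound 3 `CSc1cc(C)nc(SC)c1NC(=O)N(Cc1ccccc1)Cc1ccc(-c2cc[nH]n2)cc1` gives 55 nM. On these three numbers compound 2 stands highest, and its gaps to compound 3 and to compound 1 both lie beyond the usual scatter of the read-out, so compound 2 is the weakest inhibitor of the three as measured.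

Compound 4 `Cc1cc(C)c(NC(=O)N(Cc2ccc(-c3cccs3)cc2)C2CCCCCC2)c(C)c1` has not yet been measured in this assay. It differs from compound 2 in one place: thiophen-2-yl in place of 5-methyl-1H-1,2,4-triazol-3-yl on an aromatic carbon. Within the data shown here, no step between two measured compounds isolates this change, so any expectation rests on the spread of the three numbers. The step from compound 2 to compound 4 is expected to run towards a lower number, beyond the scatter, because compound 1 gives 36 nM and compound 3 gives 55 nM, and neither of these two carries a triazole. The expected step is a 2.4-fold lower number from compound 2 to compound 4 (0.38 log units; beyond the scatter). Compound 4 is estimated at 50 nM, with a range from 20 nM to 130 nM.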

Compound 4, half-maximal inhibitory concentration: 22 nM
For compound 4 the middle estimate is 2.3-fold (0.36 log units) above the measured one, and the stated range covers the measured number.
By their numbers in this assay, from the lowest: compounds 4, 1 and 3 (each within the scatter of the next, the first and the last beyond it); then compound 2.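

In this assay, this position is now seen to respond to the choice of five-membered aromatic ring: a 5.5-fold lower number from compound 2 to compound 4 (0.74 log units; beyond the scatter) on an aromatic carbon para to a large group, with the rest of the structure unchanged. The change need not keep a hydrogen-bond donor at this position, as thiophen-2-yl has 0 hydrogen-bond donors and 5-methyl-1H-1,2,4-triazol-3-yl has 1. The change also alters the ring hetero atoms and removes the methyl group, and no measurement on these compounds separates those parts or accounts for the step.

Still open, as far as these compounds go, is how an unsubstituted phenyl ring, a pyridine ring or a dimethylamino group would read at the same position. Also open, from the compounds shown here alone, is whether a methyl group on the thiophene would shift the number of compound 4.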